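Swapping the aryl group on an inactive compound

The source may report more compounds than this note shows. Statements on the series, on what has been measured and on what is new or still open speak of the compounds shown alone.

Compound 1 `O=C(N/N=C/c1ccccc1)Nc1ccc(Oc2ccnc3[nH]ccc23)c(F)c1`: 2500 nM
Compound 2 `O=C(N/N=C/c1cccc(Cl)c1Cl)Nc1ccc(Oc2ccnc3[nH]ccc23)c(F)c1`: "not active" (no number reported)

In a functional assay on A549 cells (Homo sapiens) for antiproliferative activity, read by MTT assay, with a stated time of 72 h (a lower number here means a stronger inhibitor, a higher number a weaker inhibitor), compound 2 is recorded as "not active" (no number reported), so it has no single number to compare. Only compound 1 has a number, at 2500 nM. Compound 3 `COc1ccc(/C=N/NC(=O)Nc2ccc(Oc3ccnc4[nH]ccc34)c(F)c2)cc1` is still unmeasured. The structural change is 4-methoxyphenyl in place of 2,3-dichlorophenyl on a carbon with a double bond to nitrogen, with 4-methoxyphenyl in place of 2,3-dichlorophenyl on a carbon with a double bond to nitrogen. In this assay a step toward stronger inhibition than compound 2 is expected, of a size that would bring a measurable number close to that of compound 1 at 2500 nM. Compound 3 is estimated at 3000 nM, with an expected range of 1000 nM to 10000 nM.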

Compound 3, half-maximal inhibitory concentration: 3980 nM
Beside the measured number, compound 3's estimate is 1.3-fold (0.12 log units) below it; the range from low to high includes it.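

In this assay the step is a 1.6-fold higher number from compound 1 to compound 3 (0.20 log units; within the scatter), so methoxy in place of hydrogen on an aromatic carbon leaves the two compounds indistinguishable. Compound 2 has no number, so its step to compound 3 cannot be read, but 4-methoxyphenyl gives a measurable value where 2,3-dichlorophenyl is recorded as not active. Nothing available explains this difference.

From the compounds shown here alone, it remains open whether the loss follows from the chlorines themselves. A ring with one chlorine, or with an amine or a carboxylic acid, could help separate these possibilities.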